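The source may report more compounds than this note shows. Statements on the series, on what has been measured and on what is new or still open speak of the compounds shown alone.

In an assay on Cortex for displacement of a labelled ligand from adenosine receptor A1 (Rattus norvegicus) (a higher number here means a weaker inhibitor, a lower number a stronger inhibitor), compound 1 `CCCn1c(=O)c2nc(-c3ccccc3)[nH]c2n(C)c1=O` gives 6.96 nM. Within the data shown here, of the two numbers measured so far, that of compound 1 is the larger, but compound 2 `CCCn1c(=O)n(C)c(=O)c2[nH]c(-c3ccccc3)nc21` gives 6.3 nM in this assay, and the gap between the two lies within the usual scatter, so neither is separated from the other. Compound 3 `CCCn1c(=O)c2nc(-c3ccc(O)cc3)[nH]c2n(C)c1=O` differs from compound 1 by hydroxy in place of hydrogen on an aromatic carbon. Among the measured compounds shown here, no measured pair shows the effect of this change, so its size is uncertain; a step within the scatter, if anything toward a lower number, is expected. Compound 3 is therefore estimated at 5 nM in this assay, with a range from 1.5 nM to 15 nM. This expected step amounts to a 1.4-fold lower number from compound 1 to compound 3 (0.14 log units; within the scatter).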

Compound 3, inhibition constant: 1.28 nM
Compound 3: the middle estimate sits 3.9-fold (0.59 log units) above what was measured, outside the stated range (below it).
By their numbers in this assay, from the lowest: compound 3; then compounds 2 and 1 (each within the scatter of the next).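

In this assay, among these compounds, the change from phenyl to 4-hydroxyphenyl gives a 5.4-fold lower number from compound 1 to compound 3 (0.74 log units; beyond the scatter) and so yields the first step here that lies beyond the scatter. This shows that the place para to a large group on the six-membered aromatic ring accepts hydroxy and that the number responds to a substitution there. Nothing measured here accounts for the size of this step. The compounds shown leave open whether a methoxy group or an amine at the same place would give a similar step, and whether hydroxy would have the same effect on compound 2.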